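Methyl additions on a small aminoheteroaryl series

The source may hold more compounds than are shown below. What is called first, only, known or untested is meant among the compounds shown, and "the series" means these compounds.

Compound 1 `Nc1oncc1-c1ccccc1` is the reference; in an assay on isolated protein for inhibition of Tryptophan 2,3-dioxygenase (Homo sapiens), read by fluorescence and mass spectrometry, with stated times of 5 min and 15 min (on this read-out lower numbers stand for stronger inhibition and higher numbers for weaker inhibition), compound 1 gives 140 nM. Compound 2 `Cc1noc(N)c1-c1ccccc1` differs from it by methyl in place of hydrogen on an aromatic carbon and in this assay compound 2 gives 25000 nM, a step of a 180-fold higher number from compound 1 to compound 2 (2.25 log units; beyond the scatter). Compound 3 `Nc1oncc1-n1cccn1` carries another group on the core; the difference between the cores of compound 1 and compound 3 is not broken down here. In this assay compound 3 gives 290 nM. Compound 4 `Cc1ccn(-c2cnoc2N)n1`, unmeasured, differs from compound 3 by methyl in place of hydrogen on an aromatic carbon. This is the same kind of change as from compound 1 to compound 2, not the same: there the methyl entered on a five-membered aromatic ring with 1 nitrogen and 1 oxygen, next to the ring atom that bears a group of 6 heavy atoms; here it enters on a five-membered aromatic ring with 2 nitrogen, two ring bonds from that ring atom. Among the compounds with values here, for compound 4 in this assay a step of a 3.1-fold higher number from compound 3 to compound 4 (0.49 log units; beyond the scatter) is expected, smaller than the earlier one since the only guide, a 180-fold higher number from compound 1 to compound 2 (2.25 log units; beyond the scatter), sits on a different ring. Compound 4 is estimated at 900 nM, between 250 nM and 4000 nM.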

Compound 4, half-maximal inhibitory concentration: 1600 nM
The estimate for compound 4 lay 1.8-fold (0.25 log units) below the measured number; the measured number falls inside the stated range.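

Methyl in place of hydrogen on an aromatic carbon gives a higher number on both cores in this assay, and on the core of compound 3 the result is a 5.5-fold higher number from compound 3 to compound 4 (0.74 log units; beyond the scatter). The direction carries over between these two pairs, but the size of the step does not: the same change on two cores in this assay, a 180-fold higher number (2.25 log units; beyond the scatter) from compound 1 to compound 2 and a 5.5-fold higher number (0.74 log units; beyond the scatter) from compound 3 to compound 4, 32-fold (1.51 log units) apart, beyond the scatter of two such steps. With the methyl on a different ring in each pair, these two pairs cannot separate the influence of the core from that of the ring and place receiving the methyl, and they set no rule for other cores.

As far as these compounds go, it remains open whether ethyl, methoxy or chlorine in the same place on the core of compound 3 would follow the methyl. Also open, from the compounds shown here alone, is how either core responds when an acetamide replaces the amine.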